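The compounds below may be only part of what the source reports. "The series", "measured", "known", "first", "only" and "open" are said of these compounds alone.

Measured in a functional assay on THP-1 cells (Homo sapiens) for inhibition, read by ELISA, with stated times of 2 h and 48 h; a lower number here means a stronger inhibitor, a higher number a weaker inhibitor:
- compound 1 `[O-]/[N+](=C\c1cn(-c2ccc(C(F)(F)F)cc2)nn1)Cc1ccccc1`: 15400 nM
- compound 2 `CC(C)(C)/[N+]([O-])=C/c1cn(-c2ccccc2)nn1`: > 20000 nM, a limit of the assay
- compound 3 `COc1ccc(-n2cc(/C=[N+](\[O-])C(C)(C)C)nn2)cc1`: 13500 nM

Compound 3 gives 13500 nM and compound 1 gives 15400 nM, two numbers within the scatter of each other. Compound 2 gives only a limit and no number.

Compound 4 `CC(C)(C)/[N+]([O-])=C/c1cn(-c2ccc(C(F)(F)F)cc2)nn1` has trifluoromethyl in place of methoxy on an aromatic carbon, compared with compound 3: trifluoromethyl in place of methoxy on an aromatic carbon. Going by the values given here, the one measured step bearing on this change is an at least 1.4-fold lower number from compound 2 to compound 3 (0.17 log units; that floor lies within the scatter), with methoxy in place of hydrogen on an aromatic carbon, and its floor lies within the scatter. Compound 1 also carries trifluoromethyl and gives 15400 nM. On this basis, no step beyond the scatter is expected in this assay, in either direction. The expected change is a 1.1-fold higher number from compound 3 to compound 4 (0.05 log units; within the scatter). Compound 4 may also end at the limit of > 20000 nM in this assay, at which 1 of the 3 values shown sits. The estimate for compound 4 is 15000 nM, with an expected range of 7000 nM to 30000 nM.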

Compound 4, half-maximal inhibitory concentration: 14400 nM
Estimate against measurement, compound 4: 1.0-fold (0.02 log units) above, within the range that was stated.
By their numbers in this assay, from the lowest: compounds 3, 4 and 1 (each within the scatter of the next). At a limit, above all of these: compound 2.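

In this assay, this position on the aromatic ring does not tell trifluoromethyl from methoxy: a 1.1-fold higher number from compound 3 to compound 4 (0.03 log units; within the scatter). With trifluoromethyl in place, the group on the double-bonded nitrogen does not separate tert-butyl from benzyl either: a 1.1-fold lower number from compound 1 to compound 4 (0.03 log units; within the scatter). Against hydrogen on the ring, the comparison yields only a floor, an at least 1.3-fold lower number from compound 2 to compound 4 (0.14 log units; that floor lies within the scatter), and compound 2 stands at a limit of the assay: the limit of > 20000 nM in this assay, at which 1 of the 4 values shown sits.

As far as these compounds go, whether an amine or a carboxylic acid at this ring position, or a longer chain on the nitrogen in place of tert-butyl, would give a step beyond the scatter stays open. From the compounds shown here alone, with no number for compound 2, the true size of the step from hydrogen to either group also stays open.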